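Notes on compound 4: chloro in place of hydrogen

This account rests on a few compounds, and the source may have more. Where it says the series, first, only, none or still open, it means among the compounds named here.

Three compounds of this series have numbers in a functional assay on C6 cells (Rattus norvegicus) for cytotoxicity, read by MTT assay, with a stated time of 24 h; a lower number here means a stronger inhibitor, a higher number a weaker inhibitor. Compound 1 `CN(C)CCN1CCN(CC(=O)Nc2ccc(-c3nc4ccccc4o3)cc2)CC1` gives 7010 nM. Compound 3 `Cc1cc(-c2nc3ccccc3o2)ccc1NC(=O)CCl` gives 27200 nM, the highest of the two numbers; its nearest neighbour is compound 1, whose number is lower by an amount beyond the scatter. Compound 2 `Cc1cc(-c2nc3cc(F)ccc3o2)ccc1NC(=O)CCl` reaches only a limit of the assay, > 100000 nM. Going by the values given here, the one measured step, an at least 3.6-fold lower number from compound 2 to compound 3 (0.56 log units; beyond the scatter), rests on (the limit of > 100000 nM in this assay, at which 1 of the 3 values shown sits), so its size is known only as a lower bound.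

Compound 4 `Cc1cc(-c2nc3cc(Cl)ccc3o2)ccc1NC(=O)CCl` differs from compound 3 by chloro in place of hydrogen on an aromatic carbon. Among the compounds with values here, this is the same position that carries fluoro in compound 2, so the only step that bears on the change is an at least 3.6-fold lower number from compound 2 to compound 3 (0.56 log units; beyond the scatter), read in the opposite direction: a halogen at this position gave a higher number in this assay. A chloro there is expected to move the number upward as well, by at least a modest amount; whether it also runs into the limit of the assay cannot be told from the numbers in hand. The expected step is therefore a 2.6-fold higher number from compound 3 to compound 4 (0.41 log units; beyond the scatter). Compound 4 is estimated at 70000 nM, with a range from 20000 nM to 250000 nM.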

Compound 4, half-maximal inhibitory concentration: > 100000 nM
Compound 4 gave a limit, no number; the forecaster's own chance of this, stated with the estimate: 50%; middle value at least 1.4-fold (0.15 log units) away from the limit.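

In this assay, the change to chloro gives an at least 3.6-fold higher number from compound 3 to compound 4 (0.56 log units; beyond the scatter). Fluoro is therefore no longer the only halogen at this aromatic carbon to go with a higher number than hydrogen: both halogens shown there now do, and among these three compounds only compound 3, with hydrogen at this place, gives a number rather than a limit. The step between chloro and fluoro cannot be read, so the data do not order the two halogens, because compound 2 and compound 4 both stand at a limit of the assay: the limit of > 100000 nM in this assay, at which 2 of the 4 values shown sit.

As far as these compounds go, the true size of the loss on adding either halogen stays open, as does the question of whether it depends on the halogen at all, since only a lower bound is available for each. Also open, from the compounds shown here alone, is whether a group that is not a halogen at this aromatic carbon, such as a methoxy group or an amine, would keep a readable number as hydrogen does, or would also reach the limit.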